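A few compounds are considered here, and "the series" means these few. Any claim that something is new, unique, unknown or untested is made for them only; others in the source may bear on it.

Measured so far:
- compound 1, `O=S(=O)(Nc1ccc(O)c(Sc2ncn[nH]2)c1)c1c(Cl)cccc1Cl`: 48.4%
- compound 2, `O=S(=O)(Nc1ccc(O)c(Sc2ncn[nH]2)c1)c1ccc(Cl)cc1`: 56.4%

Both compounds were tested in an assay on isolated protein for inhibition of RAC-alpha serine/threonine-protein kinase (Homo sapiens), read by fluorescence, with a stated time of 30 min, tested at 10 uM; a lower number here means less inhibition, a higher number more inhibition at the concentration tested (going by the name of the read-out). Compound 1 gives 48.4%, and compound 2 gives 56.4%, which is the higher of the two numbers shown, though the only step between them, a number 8 percentage points higher from compound 1 to compound 2 (within the scatter), lies within the scatter of this assay, so the two cannot be told apart with confidence.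

Compound 3, `CS(=O)(=O)Nc1ccc(O)c(Sc2ncn[nH]2)c1`, has not yet been measured. Compared with compound 2 the change is methyl in place of 4-chlorophenyl on a sulfonyl sulfur. This removes the whole aromatic ring on the sulfonyl sulfur and leaves only a single carbon there. Among the compounds with values here, the one measured step, from compound 1 to compound 2, swapped one chlorinated ring for another and stayed within the scatter; it says nothing about what happens when the ring itself is taken away. Within the data shown here, no measured step therefore bears directly on this change.

With only that to go on, compound 3 is expected to show somewhat weaker inhibition, an estimated 35%, in the range 10% to 60%, a step of a number 21.4 percentage points lower from compound 2 to compound 3 (beyond the scatter) from compound 2 that is itself uncertain.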

Compound 3, a percentage reported as inhibition, at one concentration (the size of the read-out at that concentration, not a potency): 14.3%
Compound 3: the middle estimate sits 20.7 percentage points above what was measured; measured number inside the range.
By their numbers in this assay, from the lowest: compound 3; then compounds 1 and 2 (each within the scatter of the next).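

Within the data shown here, compound 1 and compound 2 showed only that one chlorinated ring on the sulfonyl sulfur could stand in for another in this assay; the new result shows that this position does respond to change when the ring is removed altogether. Methyl in place of 4-chlorophenyl gives a clear drop (a number 42.1 percentage points lower from compound 2 to compound 3 (beyond the scatter)), and methyl in place of 2,6-dichlorophenyl gives a drop of the same kind (a number 34.1 percentage points lower from compound 1 to compound 3 (beyond the scatter)), so among these three compounds both of those with a chlorinated phenyl ring stand apart from the one with methyl, and none goes against that. Nothing available explains why inhibition falls with this change.

These compounds cannot separate the loss of the ring from the loss of its chlorine, and plain phenyl on the sulfonyl sulfur would bear on that, while cyclohexyl or a longer chain such as butyl would ask whether an aromatic ring is needed there at all. From the compounds shown here alone, each number is also a reading at one concentration rather than a potency, so how far these compounds differ across a range of concentrations remains open.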